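Benzylamine restored in place of ethylpiperazine

A few compounds are considered here, and "the series" means these few. Any claim that something is new, unique, unknown or untested is made for them only; others in the source may bear on it.

Measured so far:
compound 1, `COc1ccc(CNCc2c(OC)cc(Oc3cccc(Nc4ccccc4)c3)cc2OC)cc1`: 2620 nM
compound 2, `CCN1CCN(Cc2c(OC)cc(Oc3cccc(Nc4ccccc4)c3)cc2OC)CC1`: > 20000 nM

In a functional assay on HCT-116 cells (Homo sapiens) for inhibition, read by MTT assay, with a stated time of 72 h (a higher number here means a weaker inhibitor, a lower number a stronger inhibitor), compound 1 gives 2620 nM. For compound 2 the entry > 20000 nM is a limit of the assay, not a number, so compound 2 stands at the weak end of what is shown. For the measured compounds named here, the only measured step, an at least 7.6-fold higher number from compound 1 to compound 2 (0.88 log units; beyond the scatter), runs up to that limit (the limit of > 20000 nM in this assay, at which 1 of the 2 values shown sits).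

Compound 3, `COc1cc(Oc2cccc(Nc3ccccc3)c2)cc(OC)c1CNCc1ccc(O)cc1`, differs from compound 2 by (4-hydroxybenzyl)amino in place of 4-ethylpiperazin-1-yl on a saturated chain carbon bound to an aromatic carbon. This largely reverses the measured step, keeping a benzylamino group as in compound 1. Because compound 1 gives 2620 nM, compound 3 is expected close to it, at 3000 nM, within 1000 nM to 10000 nM. A downward step is expected, an at least 6.6-fold lower number from compound 2 to compound 3 (0.82 log units; beyond the scatter).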

Compound 3, half-maximal inhibitory concentration: 3360 nM
Compound 3: middle estimate off by 1.1-fold (0.05 log units), on the low side, and the stated range covers the measured number.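

In this assay, the loss seen with 4-ethylpiperazin-1-yl on this saturated chain carbon is reversed by (4-hydroxybenzyl)amino: an at least 5.9-fold lower number from compound 2 to compound 3 (0.77 log units; beyond the scatter). The value for compound 2 in that step is a limit of the assay, not a number. The benzylamino group also tolerates a change at its oxygen, as hydrogen in place of methyl gives a 1.3-fold higher number from compound 1 to compound 3 (0.11 log units; within the scatter).

Open, from the compounds shown here alone, is whether a carboxylic acid or a fluorine on the benzyl ring keeps the number near those of compound 1 and compound 3. Going by these compounds, a morpholine or a longer chain in place of benzyl also remains untested here.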